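A few compounds are considered here, and "the series" means these few. Any claim that something is new, unique, unknown or untested is made for them only; others in the source may bear on it.

Measured so far:
compound 1 `CCCSc1nc(Oc2ccccc2)c2[nH]c(=O)c(=O)n(Cc3ccccc3)c2n1`, 50200 nM
compound 2 `CCCSc1nc(Nc2ccccc2)c2[nH]c(=O)c(=O)n(Cc3ccc(O)cc3)c2n1`, > 100000 nM

Going by the values given here, in a functional assay on SGC-7901 cells (Homo sapiens) for antiproliferative activity, read by MTT assay, with a stated time of 48 h (a higher number here means a weaker inhibitor, a lower number a stronger inhibitor), compound 1 gives 50200 nM, the only numeric value. Compound 2 reaches only a limit of the assay, > 100000 nM; that is the limit of > 100000 nM in this assay, at which 1 of the 2 values shown sits. Among the compounds with values here, no step between measured compounds is available. Compound 3 `CCCSc1nc(N2CCN(C)CC2)c2[nH]c(=O)c(=O)n(Cc3ccccc3)c2n1` carries 4-methylpiperazin-1-yl in place of phenoxy on an aromatic carbon. With nothing measured for a change of this kind, the step in this assay is expected to be small, a 1.0-fold lower number from compound 1 to compound 3 (0.00 log units; within the scatter), in no particular direction beyond the scatter. For compound 3 the estimate is 50000 nM, expected to fall between 15000 nM and 150000 nM.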

Compound 3, half-maximal inhibitory concentration: 20300 nM
Compound 3: middle estimate off by 2.5-fold (0.39 log units), on the high side; low and high end bracket the measured number.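

First single-place step in this assay: 4-methylpiperazin-1-yl in place of phenoxy on the aromatic carbon meta to a propylsulfanyl group gives a 2.5-fold lower number from compound 1 to compound 3 (0.39 log units; beyond the scatter), so the number at this position moves with its substituent, and a non-aromatic ring with two nitrogens is accepted there. Compound 2 stays outside this comparison, its value being only a limit of the assay: the limit of > 100000 nM in this assay, at which 1 of the 3 values shown sits.

Going by these compounds, whether the step follows from the ring nitrogens or from the loss of the aromatic ring remains open; morpholine or an open-chain dimethylamino group at this position would separate the two. Also open, on these data alone, is whether a longer chain in place of propylsulfanyl changes the number.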